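Moving Away from Bromo in Compound 3

The source may report more compounds than this note shows. Statements on the series, on what has been measured and on what is new or still open speak of the compounds shown alone.

In a functional assay on the whole organism (strain Wistar) with Rattus norvegicus as the target, read by paw edema (a higher number here means that more compound is needed for the effect, a lower number that less compound is needed), compound 1 `CCC(=O)OCc1cc(-n2nc(C(F)(F)F)cc2-c2ccc(SC)cc2)ccc1S(N)(=O)=O` gives 60 mg/kg, and compound 2 `CCC(=O)OCc1cc(-n2nc(C(F)(F)F)cc2-c2ccc(Br)cc2)ccc1S(N)(=O)=O` gives 17 mg/kg, the lower of the two numbers. Compound 3 `CCC(=O)OCc1cc(-n2nc(C(F)(F)F)cc2-c2ccc(OC)c(C)c2)ccc1S(N)(=O)=O` has not been measured yet and differs from compound 2 as follows: 4-methoxy-3-methylphenyl in place of 4-bromophenyl on an aromatic carbon. For the measured compounds named here, the one measured step at this aromatic group, a 3.5-fold lower number from compound 1 to compound 2 (0.55 log units; beyond the scatter), put bromo in place of methylsulfanyl and was modest. Going by that single step, leaving bromo is expected to bring a modest rise in this assay, a 2.2-fold higher number from compound 2 to compound 3 (0.35 log units; beyond the scatter). For compound 3 the estimated value is 38 mg/kg, with an expected range of 13 mg/kg to 110 mg/kg.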

Compound 3, dose for half-maximal effect: 10.9 mg/kg
Compound 3: the middle estimate sits 3.5-fold (0.54 log units) above what was measured; the whole stated range lies above it.
By their numbers in this assay, from the lowest: compounds 3 and 2 (each within the scatter of the next); then compound 1.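

In this assay the swap at this position gives a 1.6-fold lower number from compound 2 to compound 3 (0.19 log units; within the scatter) and so keeps the number level with bromo, even though the new ring carries two groups, one with an oxygen. The comparison with the methylsulfanyl compound shows a 5.5-fold lower number from compound 1 to compound 3 (0.74 log units; beyond the scatter) and so the drop seen with bromo is not unique to bromo. No measured evidence explains these results.

Methoxy and methyl enter together, so what each contributes alone stays open. Going by these compounds, how an amine or a carboxylic acid on this phenyl ring would read in this assay also stays open.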